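Benzoxazolyl for pyridinyl at the aryl position: expected clearance

The compounds below may be only part of what the source reports. "The series", "measured", "known", "first", "only" and "open" are said of these compounds alone.

Compound 1 `Nc1ccc(S(=O)(=O)N2CCN(c3ncc(C(O)(C(F)(F)F)C(F)(F)F)cc3Br)CC2)cn1`: 32 mL.min-1.g-1
Compound 2 `Cn1cc(-c2cc(C(O)(C(F)(F)F)C(F)(F)F)cnc2N2CCN(S(=O)(=O)c3ccc(N)nc3)CC2)cn1`: 44 mL.min-1.g-1
Compound 3 `Nc1ccc(S(=O)(=O)N2CCN(c3ncc(C(O)(C(F)(F)F)C(F)(F)F)cc3-c3ccncc3)CC2)cn1`: 31 mL.min-1.g-1

In an ADME assay (liver) for metabolic stability, with Liver microsome (Rattus norvegicus) as the target, using microsomes and NADPH, with a stated time of 30 min, tested at 1 uM (on this read-out lower numbers stand for slow clearance and higher numbers for fast clearance), compound 3 shows the lowest of the three numbers, yet it is not set apart: the steps of a 1.0-fold lower number from compound 1 to compound 3 (0.01 log units; within the scatter) and a 1.4-fold lower number from compound 2 to compound 3 (0.15 log units; within the scatter) both lie within the scatter. Compound 4 `Nc1ccc(S(=O)(=O)N2CCN(c3ncc(C(O)(C(F)(F)F)C(F)(F)F)cc3-c3ccc4ocnc4c3)CC2)cn1` differs from compound 3 by 1,3-benzoxazol-5-yl in place of pyridin-4-yl on an aromatic carbon. Both measured steps at this position, a 1.4-fold higher number from compound 1 to compound 2 (0.14 log units; within the scatter) and a 1.0-fold lower number from compound 1 to compound 3 (0.01 log units; within the scatter), stayed within the scatter, so aromatic groups of different kinds here have so far left the read-out essentially unchanged. A benzoxazolyl group has not been tested at this position, so the step of a 1.3-fold higher number from compound 3 to compound 4 (0.11 log units; within the scatter) is an expectation of little change beyond the scatter. Compound 4 is estimated at 40 mL.min-1.g-1, within a range of 20 mL.min-1.g-1 to 80 mL.min-1.g-1.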

Compound 4, intrinsic clearance in microsomes: 120 mL.min-1.g-1
Compound 4: middle estimate off by 3.0-fold (0.48 log units), on the low side; the measured number lies above the stated range.
By their numbers in this assay, from the lowest: compounds 3, 1 and 2 (each within the scatter of the next); then compound 4.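

In this assay this position proved sensitive to the aromatic group after all, since a 3.9-fold higher number from compound 3 to compound 4 (0.59 log units; beyond the scatter) and a 2.7-fold higher number from compound 2 to compound 4 (0.44 log units; beyond the scatter) and also a 3.8-fold higher number from compound 1 to compound 4 (0.57 log units; beyond the scatter) all lie beyond the scatter. Among the aromatic groups shown, 1,3-benzoxazol-5-yl alone sets its compound apart, while the bromo, 1-methyl-1H-pyrazol-4-yl and pyridin-4-yl compounds remain within the scatter of one another. No evidence here bears on the reason for this rise.

Going by these compounds, whether a phenyl or naphthyl group would give a similar rise stays open. So does the part played by the oxygen and nitrogen of the benzoxazolyl group.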